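Chloro for methoxy in a weakly active series

The source may hold more compounds than are shown below. What is called first, only, known or untested is meant among the compounds shown, and "the series" means these compounds.

Compound 1 `COc1cccc(N2C(=O)COc3ccc(-c4cnc(Cl)c(NS(=O)(=O)c5ccc(F)cc5)c4)cc32)c1`: > 40000 nM (a limit)
Compound 2 `COc1ncc(-c2ccc3c(c2)N(c2ccc(F)cc2)C(=O)CO3)cc1NS(=O)(=O)c1ccc(F)cc1`: 36400 nM

Among the compounds with values here, in a functional assay on HepG2 cells (Homo sapiens) for antiproliferative activity, read by MTT assay, with a stated time of 72 h (a lower number here means a stronger inhibitor, a higher number a weaker inhibitor), compound 2 gives 36400 nM, the only true number so far. Compound 1 is recorded at a limit of the assay, > 40000 nM, and not at a number.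

Compound 3 `O=C1COc2ccc(-c3cnc(Cl)c(NS(=O)(=O)c4ccc(F)cc4)c3)cc2N1c1ccc(F)cc1` differs from compound 2 by chloro in place of methoxy on an aromatic carbon, next to the ring nitrogen and ortho to a ((4-fluorophenyl)sulfonyl)amino group: chloro in place of methoxy on an aromatic carbon.

Within the data shown here, no measured step isolates a single change, so the size of this one has not been observed. In this assay no shift beyond the scatter is expected, and the expectation starts from compound 2 at 36400 nM. Chloro also occurs in compound 1, whose result is the limit > 40000 nM. Compound 3 may therefore well be reported only as a limit.

The expected change is a 1.0-fold higher number from compound 2 to compound 3 (0.02 log units; within the scatter), an estimate that stays within the scatter. For compound 3 the estimated value is 38000 nM, with an expected range of 15000 nM to 80000 nM.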

Compound 3, half-maximal inhibitory concentration: > 40000 nM
Compound 3 ended at the assay's limit; the forecaster's own chance of this, stated with the estimate: 45%; at least 1.0-fold (0.02 log units) between middle value and limit.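

Chloro in place of methoxy on an aromatic carbon, next to the ring nitrogen and ortho to a ((4-fluorophenyl)sulfonyl)amino group, gives in this assay an at least 1.0-fold higher number from compound 2 to compound 3 (0.04 log units; that floor lies within the scatter). Within the data shown here, this is the first step at this position, and it is only a floor: it shows no lowering of the number with chloro and gives no upper size for the change. The step on the amide-type nitrogen between the two compounds that sit at a limit cannot be read, and the assay ceiling now covers most of the series: the limit of > 40000 nM in this assay, at which 2 of the 3 values shown sit.

Among these compounds, whether a methyl, a nitrile or an amine on this same aromatic carbon would bring the number well clear of the limit remains open, with methoxy in compound 2 the only group here that gives a true number. Also open, on these data alone, is how the amide-type nitrogen would respond to a longer chain or a carboxylic acid-bearing group on a background that reads clear of the limit.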